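Methoxy Placement on a Shared Phenoxy Core

The source may hold more compounds than are shown below. What is called first, only, known or untested is meant among the compounds shown, and "the series" means these compounds.

Three compounds were measured in an ADME assay on HepG2 cells (Homo sapiens) for cytotoxicity, read by luminescence, CellTiter-Glo and ATP content, with a stated time of 72 h; on this read-out higher numbers stand for an effect only at larger amounts of compound and lower numbers for an effect already at smaller amounts:
compound 1 `COc1cccc(Oc2ccc3c(NCCCNCc4ccco4)ccnc3c2)c1`, 15500 nM
compound 2 `CC(C)(C)c1ccc(-c2ccc3c(NCCCNCc4ccco4)ccnc3c2)cc1`, 3150 nM
compound 3 `c1ccc(Oc2ccc3c(NCCCNCc4ccco4)ccnc3c2)cc1`, 15200 nM

Compound 3 stands second highest of the three numbers; the step of a 1.0-fold lower number from compound 1 to compound 3 (0.01 log units; within the scatter) lies within the scatter, while a 4.8-fold higher number from compound 2 to compound 3 (0.68 log units; beyond the scatter) lies beyond it. Compound 4 `COc1ccccc1Oc1ccc2c(NCCCNCc3ccco3)ccnc2c1` differs from compound 3 by methoxy in place of hydrogen on an aromatic carbon. For the measured compounds named here, the one measured step that bears on this change is the removal of a methoxy from the same phenoxy group, a 1.0-fold lower number from compound 1 to compound 3 (0.01 log units; within the scatter), which stayed within the scatter. On that basis compound 4 is expected to show no step beyond the scatter in this assay, an estimated 1.0-fold lower number from compound 3 to compound 4 (0.01 log units; within the scatter). Compound 4 is therefore estimated at 15000 nM, with a range from 7000 nM to 32000 nM.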

Compound 4, half-maximal effective concentration: 6500 nM
For compound 4 the middle estimate is 2.3-fold (0.36 log units) above the measured one; measured number outside the range, below it.
By their numbers in this assay, from the lowest: compound 2; then compound 4; then compounds 3 and 1 (each within the scatter of the next).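

In this assay, adding methoxy to the phenoxy group is not without consequence at every placement: the 2-methoxyphenoxy group gives a 2.3-fold lower number from compound 3 to compound 4 (0.37 log units; beyond the scatter). Placement alone matters here, since exchanging 3-methoxyphenyl for 2-methoxyphenyl on the oxygen gives a 2.4-fold lower number from compound 1 to compound 4 (0.38 log units; beyond the scatter). Even so, this change does not reach the number of the 4-(tert-butyl)phenyl group, as a 2.1-fold higher number from compound 2 to compound 4 (0.31 log units; beyond the scatter) shows.

Nothing available explains why the two methoxy placements differ. As far as these compounds go, it remains open whether an ethoxy or a dimethylamino group in place of this methoxy would give a similar step.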